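Working notes: from compound 2 to compound 3

The source may report more compounds than this note shows. Statements on the series, on what has been measured and on what is new or still open speak of the compounds shown alone.

Measured so far in a functional assay on PC-3 cells (Homo sapiens) for antiproliferative activity, read by MTT assay, with a stated time of 48 h; on this read-out higher numbers stand for weaker inhibition of growth and lower numbers for stronger inhibition of growth
- compound 1 `Cc1ccc(-c2cnc(N(Cc3ccccc3)Cc3ccc(C(=O)NO)cc3)s2)cc1` gives 10400 nM
- compound 2 `Cc1ccc(OCCCN(Cc2ccc(C(=O)NO)cc2)c2ncc(-c3ccc(C)cc3)s2)cc1` gives 9330 nM

Among the compounds with values here, compound 2 stands level with compound 1, the only other measured compound, and the two numbers cannot be ordered. Compound 3 `Cc1ccc(-c2cnc(N(CCCCOc3ccccc3)Cc3ccc(C(=O)NO)cc3)s2)cc1` has the same atoms as compound 2, joined differently: phenoxymethyl takes the place of 4-methylphenoxy on a saturated chain carbon, three bonds along the chain from a nitrogen on an aromatic ring (phenoxymethyl in place of 4-methylphenoxy on a saturated chain carbon, three bonds along the chain from a nitrogen on an aromatic ring). Within the data shown here, no measured step isolates this change. Among the measured compounds shown here, the nearest evidence is the only step available, a 1.1-fold lower number from compound 1 to compound 2 (0.05 log units; within the scatter), where 2-(4-methylphenoxy)ethyl replaced phenyl. On that basis, no step beyond the scatter is expected in this assay. a 1.0-fold higher number from compound 2 to compound 3 (0.01 log units; within the scatter) is the expected outcome. For compound 3 the estimated value is 9500 nM, with an expected range of 4700 nM to 19000 nM in this read-out.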

Compound 3, concentration for 50% growth inhibition: 10300 nM
Compound 3: middle estimate off by 1.1-fold (0.04 log units), on the low side; low and high end bracket the measured number.
By their numbers in this assay, from the lowest: compounds 2, 3 and 1 (each within the scatter of the next).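

In this assay, phenoxymethyl in place of 4-methylphenoxy, on a saturated chain carbon, three bonds along the chain from a nitrogen on an aromatic ring, gives a 1.1-fold higher number from compound 2 to compound 3 (0.04 log units; within the scatter), so this rearrangement of the same atoms leaves compound 2 and compound 3 level. With 3-phenoxypropyl in place of phenyl on a saturated chain carbon bound to a nitrogen on an aromatic ring, the result is a 1.0-fold lower number from compound 1 to compound 3 (0.00 log units; within the scatter), so all three compounds now stand level, and none goes against this. No measurement among the data offers an explanation for this result.

On these data alone, whether an amine or a carboxylic acid in place of the phenoxy group would separate from these numbers remains open. Also open, as far as these compounds go, is whether a longer chain at this position would do so.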